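This account rests on a few compounds, and the source may have more. Where it says the series, first, only, none or still open, it means among the compounds named here.

Measured compounds in a functional assay on MCF7 cells (Homo sapiens) for cytotoxicity, read by MTT assay, with a stated time of 48 h; on this read-out higher numbers stand for weaker inhibition and lower numbers for stronger inhibition:

Compound 1 `CC(C)=CCC/C(C)=C/CC/C(C)=C/CC[C@@H]1[C@@]2(C)CC/C(=N\OCc3cn(-c4c(Cl)cc([N+](=O)[O-])cc4Cl)nn3)C(C)(C)[C@@H]2CC[C@@]1(C)O`: 16600 nM
Compound 2 `CC(C)=CCC/C(C)=C/CC/C(C)=C/CC[C@@H]1[C@@]2(C)CC/C(=N\OCc3cn(-c4ccncc4)nn3)C(C)(C)[C@@H]2CC[C@@]1(C)O`: 12600 nM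
Compound 3 `COc1cccc(-n2cc(COc3ccc(/C=C4\C[C@]5(C)[C@@H](CC/C=C(\C)CC/C=C(\C)CCC=C(C)C)[C@](C)(O)CC[C@H]5C(C)(C)C4=O)cc3)nn2)c1`: 16600 nM

Compound 3 stands level with compound 1 at the digits given, the two together the highest numbers of the three; compound 2 sits a 1.3-fold lower number from compound 1 to compound 2 (0.12 log units; within the scatter), which is within the scatter. Compound 4 `COc1cc(OC)c(-n2cc(COc3ccc(/C=C4\C[C@]5(C)[C@@H](CC/C=C(\C)CC/C=C(\C)CCC=C(C)C)[C@](C)(O)CC[C@H]5C(C)(C)C4=O)cc3)nn2)c(OC)c1` differs from compound 3 in one place: 2,4,6-trimethoxyphenyl in place of 3-methoxyphenyl on an aromatic nitrogen. Among the measured compounds shown here, the only measured step that bears on it is the swap of the aryl group on the aromatic nitrogen, a 1.3-fold lower number from compound 1 to compound 2 (0.12 log units; within the scatter), and it stayed within the scatter. For the measured compounds named here, no step in this assay beyond the scatter is therefore expected for the move from compound 3 to compound 4; the expected change is a 1.0-fold lower number from compound 3 to compound 4 (0.02 log units; within the scatter). Compound 4 is estimated at 16000 nM, range 8000 nM to 35000 nM.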

Compound 4, half-maximal inhibitory concentration: 13500 nM
Compound 4: middle estimate off by 1.2-fold (0.07 log units), on the high side, and the stated range covers the measured number.
By their numbers in this assay, from the lowest: compounds 2, 4, 1 and 3 (each within the scatter of the next).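

In this assay, 2,4,6-trimethoxyphenyl in place of 3-methoxyphenyl on the aromatic nitrogen gives a 1.2-fold lower number from compound 3 to compound 4 (0.09 log units; within the scatter). The larger aryl group, with its added methoxy groups, therefore leaves the number within the scatter, and the earlier aryl swap on the core of compound 1 now has a counterpart on the core of compound 3. Nothing measured accounts for this flat response.

From the compounds shown here alone, whether an amine or a carboxylic acid on this nitrogen's aryl group would give a step beyond the scatter remains open. So does the effect of replacing the aryl group with a simple alkyl chain.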